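This account rests on a few compounds, and the source may have more. Where it says the series, first, only, none or still open, it means among the compounds named here.

Compound 1 `CC(C)(C)Cc1c(/C=C/c2ccc(Cl)cc2)sc(N)c1C(=O)c1ccc(Cl)cc1` and compound 2 `Cc1cccc(-c2sc(N)c(C(=O)c3ccc(Cl)cc3)c2CC(C)(C)C)c1` share one core and were both tested in an assay on CHO cells for displacement of a labelled ligand from adenosine receptor A1 (Homo sapiens), read by scintillation counting, tested at 10 uM; on this read-out lower numbers stand for less inhibition and higher numbers for more inhibition at the one concentration tested (going by the name of the read-out). Compound 1 gives 1%, and compound 2 gives 1%. The step of no change at the digits printed from compound 1 to compound 2 (within the scatter) shows that exchanging one aromatic group for another left the read-out unchanged , so compound 2 stands level with compound 1 . Compound 3 `Cc1noc(C)c1-c1sc(N)c(C(=O)c2ccc(Cl)cc2)c1CC(C)(C)C` differs from compound 2 by 3,5-dimethyl-1,2-oxazol-4-yl in place of 3-methylphenyl on an aromatic carbon. Among the compounds with values here, the only measured step that bears on this , no change at the digits printed from compound 1 to compound 2 (within the scatter), was flat , so in this assay a step of no change at the digits printed from compound 2 to compound 3 (within the scatter) is expected . Compound 3 is therefore estimated at 1%, within -6% to 10%.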

Compound 3, a percentage reported as inhibition, at one concentration (the size of the read-out at that concentration, not a potency): 1%
For compound 3 middle estimate and measured number coincide at the digits printed; measured number inside the range.
By their numbers in this assay, from the lowest: compounds 1, 2 and 3 (each within the scatter of the next).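

In this assay, the place next to the ring sulfur also accepts a five-membered aromatic ring with 2 hetero atoms: 3,5-dimethyl-1,2-oxazol-4-yl brings 2 hydrogen-bond acceptors where 3-methylphenyl has 0, yet the result is no change at the digits printed from compound 2 to compound 3 (within the scatter). Set against 2-(4-chlorophenyl)ethenyl, the same group gives no change at the digits printed from compound 1 to compound 3 (within the scatter). Nothing available explains this flat result.

Still open, on these data alone, is whether a carboxylic acid or a simple amine on this carbon would give a different read-out. Also open, as far as these compounds go, is whether changing the neopentyl group, shared by all three compounds, would do so.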